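The source may hold more compounds than are shown below. What is called first, only, known or untested is meant among the compounds shown, and "the series" means these compounds.

Measured so far:

- compound 1, `Cc1ccc(OCc2cn(Cc3ccc(C#N)cc3)nn2)cc1`: in an assay on isolated protein for inhibition of Aromatase (Homo sapiens), read by fluorescence and colorimetric assay, with a stated time of 30 min (a higher number here means a weaker inhibitor, a lower number a stronger inhibitor), compound 1 gives 4170 nM
- compound 2, `N#Cc1ccc(OCc2cn(Cc3ccccc3)nn2)cc1`: in this assay compound 2 gives 1360 nM

Of the two compounds measured, compound 2 has the lower number, and the gap to compound 1 is larger than the usual scatter of repeated measurements, so compound 2 is the stronger inhibitor of the pair. Going by the values given here, the two structures differ in more than one place, so no single step between them is given; only the two values stand side by side.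

Compound 3, `Cc1ccc(OCc2cn(Cc3ccccc3)nn2)cc1`, is not yet measured. It arises from compound 2 by a single change: methyl in place of cyano on an aromatic carbon. After this change no nitrile remains anywhere in the molecule. Compound 1, which keeps a nitrile on its other ring, already shows the higher number of the two, and compound 3 gives up the nitrile entirely. On that basis the step is expected to go toward weaker inhibition, and by more than the scatter. The expected step is a 5.9-fold higher number from compound 2 to compound 3 (0.77 log units; beyond the scatter). The estimate for compound 3 in this assay is 8000 nM, with a plausible range from 2500 nM to 25000 nM.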

Compound 3, half-maximal inhibitory concentration: 2270 nM
Compound 3: middle estimate off by 3.5-fold (0.55 log units), on the high side, outside the stated range (below it).
By their numbers in this assay, from the lowest: compounds 2, 3 and 1 (each within the scatter of the next, the first and the last beyond it).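

In this assay, methyl in place of cyano on the six-membered aromatic ring of carbon only, para to a large group, gives a 1.7-fold higher number from compound 2 to compound 3 (0.22 log units; within the scatter), so at this position the two groups cannot be told apart and compound 3 keeps its inhibition with no nitrile anywhere in the molecule. Compound 3 is also one change away from compound 1, as the cyano group of compound 1 is absent from compound 3, and that change gives a 1.8-fold lower number from compound 1 to compound 3 (0.26 log units; within the scatter), so neither single change moves the number by more than repeated measurements usually do. No measurement at hand offers an explanation for these small steps.

The compounds shown speak only to cyano and methyl at the first position, so it remains open whether a chlorine atom, an amine or a carboxylic acid there would shift the number beyond the scatter. On these data alone, it is equally open whether a longer chain, such as ethyl or butyl, would be tolerated there as well as methyl is.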